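Changing the Sulfonyl Aryl Group in a Sulfonamide Series

The compounds below may be only part of what the source reports. "The series", "measured", "known", "first", "only" and "open" are said of these compounds alone.

Compound 2 `CC(C)Cc1cc(CNS(=O)(=O)c2ccccc2)nn1-c1ccccc1` carries a plain phenyl on its sulfonyl sulfur, and in a functional assay on HeLa cells for antagonist activity at 5-hydroxytryptamine receptor 6 (Homo sapiens), read by HTRF and cAMP accumulation, with stated times of 10 min and 30 min (a higher number here means a weaker inhibitor, a lower number a stronger inhibitor), compound 2 has "not determined" (no result reported) as its result. The nearest reported figure comes from compound 1 `CC(C)Cc1cc(CNS(=O)(=O)c2cccc3ccccc23)nn1-c1ccccc1`, whose naphthalene sulfonamide gives 2430 nM in this assay. Compound 3 `CC(C)Cc1cc(CNS(=O)(=O)Cc2cccc3ccccc23)nn1-c1ccccc1`, which carries a methylene-linked naphthalene on the sulfonyl sulfur, likewise has "not determined" (no result reported) in this assay. Among the measured compounds shown here, compound 2 therefore stands nowhere on the numbers: no measurement anchors it, and the only measured relative is compound 1.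

Compound 4 `Cc1c(Cl)cccc1S(=O)(=O)NCc1cc(CC(C)C)n(-c2ccccc2)n1` is reached from compound 2 by the change (3-chloro-2-methylphenyl in place of phenyl on a sulfonyl sulfur). With no measured starting point for compound 2, no step can be computed, and none is shown between any pair of measured compounds here. The expectation can rest only on compound 1 in this assay, where compound 1 gives 2430 nM with a different aryl group on the same sulfonyl sulfur. A value of similar order is expected for compound 4, with no direction claimed beyond the usual scatter and with a broad range on either side. Compound 4 is estimated at 1500 nM in this assay, with a range from 300 nM to 8000 nM.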

Compound 4, half-maximal inhibitory concentration: 4010 nM
Compound 4: the middle estimate sits 2.7-fold (0.43 log units) below what was measured; measured number inside the range.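

In this assay, the sulfonyl sulfur now carries a second aryl group with a number: 3-chloro-2-methylphenyl in place of naphthalen-1-yl gives a 1.7-fold higher number from compound 1 to compound 4 (0.22 log units; within the scatter), so the two compounds cannot be told apart in this read-out. This shows that, on this sulfonyl sulfur, a substituted single aromatic ring of carbon only and a naphthalene give values within the scatter of each other, though both compounds sit in the same micromolar region and neither stands out from the other. Any step involving compound 2 or compound 3 cannot be read, since neither has a single number, and nothing available here offers an explanation for the result.

Going by these compounds, what the plain phenyl itself contributes remains open, as does the separate share of the chlorine and the methyl in 3-chloro-2-methylphenyl. Also open, on these data alone, is whether a pyridine ring, a methoxy-substituted phenyl or an aryl group bearing an amine on the same sulfonyl sulfur would move the number beyond the scatter in this assay.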